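A few compounds are considered here, and "the series" means these few. Any claim that something is new, unique, unknown or untested is made for them only; others in the source may bear on it.

Three esters on the shared core were tested in an ADME assay on HepG2 2.2.15 cells (Homo sapiens) for cytotoxicity, read by MTT assay; on this read-out higher numbers stand for lower toxicity in this test and lower numbers for higher toxicity in this test: compound 1 `C=C1CC[C@@H]2[C@](C)(CO)[C@H](OC(=O)/C=C/c3ccccc3)CC[C@@]2(C)[C@@H]1C/C=C1\C=COC1=O` gives 179000 nM, compound 2 `C=C1CC[C@@H]2[C@](C)(CO)[C@H](OC(=O)c3ccco3)CC[C@@]2(C)[C@@H]1C/C=C1\C=COC1=O` gives 42000 nM, and compound 3 `C=C1CC[C@@H]2[C@](C)(CO)[C@H](OC(=O)c3cccs3)CC[C@@]2(C)[C@@H]1C/C=C1\C=COC1=O` gives 257000 nM. Compound 3 thus sits at the upper end of the series, within the scatter of compound 1 and clear of compound 2. Compound 4 `C=C1CC[C@@H]2[C@](C)(CO)[C@H](OC(C)=O)CC[C@@]2(C)[C@@H]1C/C=C1\C=COC1=O` carries methyl in place of thiophen-2-yl on a carbonyl carbon. Among the measured compounds shown here, three measured steps bear on this place. The step of a 1.4-fold higher number from compound 1 to compound 3 (0.16 log units; within the scatter) stayed within the scatter, while a 4.3-fold lower number from compound 1 to compound 2 (0.63 log units; beyond the scatter) and a 6.1-fold higher number from compound 2 to compound 3 (0.79 log units; beyond the scatter) were modest. For the measured compounds named here, no measured compound carries methyl here. A modest move back into the spread of the three values is expected, namely a 2.6-fold lower number from compound 3 to compound 4 (0.41 log units; beyond the scatter). The estimated value for compound 4 is 100000 nM, within a range of 35000 nM to 280000 nM.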

Compound 4, half-maximal cytotoxic concentration: 872000 nM
Compound 4: the middle estimate sits 8.7-fold (0.94 log units) below what was measured, and the stated range ends below it.
By their numbers in this assay, from the lowest: compound 2; then compounds 1 and 3 (each within the scatter of the next); then compound 4.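

Methyl in place of each ring-bearing or 2-phenylethenyl group raises the number in this assay beyond the scatter: the steps are (a 3.4-fold higher number from compound 3 to compound 4 (0.53 log units; beyond the scatter)) and (a 4.9-fold higher number from compound 1 to compound 4 (0.69 log units; beyond the scatter)) and, largest, (a 21-fold higher number from compound 2 to compound 4 (1.32 log units; beyond the scatter)). The acetyl ester, with no ring at this place, therefore shows the lowest toxicity in this test of the four, so neither a ring nor 2-phenylethenyl is needed for a high number here. Nothing given here accounts for this shift. On these data alone, whether a longer chain such as ethyl or propyl on the carbonyl carbon would stay near compound 4, or whether an amine on that chain would change the number, remains open.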